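Sulfonyl aryl variation in a fluoroquinolinyl sulfone series

A few compounds are considered here, and "the series" means these few. Any claim that something is new, unique, unknown or untested is made for them only; others in the source may bear on it.

Three compounds of this series have numbers in an ADME assay on microsomes from liver (Homo sapiens) for metabolic stability, tested at 2.5 uM; a higher number here means faster removal of the compound, a lower number slower removal. Compound 1 `COc1ccc(S(=O)(=O)c2cnc3c(F)cccc3c2-c2cccc(Cl)c2)cc1` gives 2.75 mL/min; compound 2 `COc1cccc(-c2c(S(=O)(=O)c3cc(Cl)cc(Cl)c3)cnc3c(F)cccc23)c1` gives 2.31 mL/min; compound 3 `COc1cccc(-c2c(S(=O)(=O)c3ccc(F)cc3)cnc3c(F)cccc23)c1` gives 2.23 mL/min. Among the compounds with values here, compound 3 thus sits within the scatter of both compound 2 and compound 1, and the one single-point step known so far, a 1.0-fold lower number from compound 2 to compound 3 (0.02 log units; within the scatter), is itself within the scatter.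

Compound 4 `COc1ccc(S(=O)(=O)c2cnc3c(F)cccc3c2-c2cccc(OC)c2)cc1` is not yet measured. It differs from compound 3 by methoxy in place of fluoro on an aromatic carbon on the aryl bound to the sulfonyl sulfur, para to a large group. Within the data shown here, no measured step changes exactly this substituent; the step from compound 2 to compound 3 is the only one at the sulfonyl aryl and was flat. Compound 1 also carries a 4-methoxyphenyl on the sulfonyl sulfur and its number lies within the scatter of compound 3. The expectation for compound 4 is therefore no step beyond the scatter, a 1.1-fold higher number from compound 3 to compound 4 (0.05 log units; within the scatter). Compound 4 is estimated at 2.5 mL/min, with a range from 1.5 mL/min to 4.2 mL/min.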

Compound 4, intrinsic clearance in a liver preparation (reported as CLH), per the amount of preparation that the assay uses: 2.87 mL/min
Compound 4: the middle estimate sits 1.1-fold (0.06 log units) below what was measured, and the stated range covers the measured number.
By their numbers in this assay, from the lowest: compounds 3, 2, 1 and 4 (each within the scatter of the next).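

In this assay, 4-methoxyphenyl in place of 4-fluorophenyl on the sulfonyl sulfur gives a 1.3-fold higher number from compound 3 to compound 4 (0.11 log units; within the scatter), so this change at the sulfonyl aryl has now been read directly and is flat. With a 1.2-fold higher number from compound 2 to compound 4 (0.09 log units; within the scatter) as well, 4-fluorophenyl, 4-methoxyphenyl and 3,5-dichlorophenyl on the sulfonyl sulfur all lie within the scatter of one another on this background. Within the data shown here, the first step at the other aryl, methoxy in place of chloro, gives a 1.0-fold higher number from compound 1 to compound 4 (0.02 log units; within the scatter), so that change is also flat in this set.

Nothing shown here explains why these steps are flat. On these data alone, whether an amine or a carboxylic acid on the sulfonyl aryl, or an ethoxy or longer chain in place of methoxy, would give a step beyond the scatter remains open.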